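The source may hold more compounds than are shown below. What is called first, only, known or untested is meant among the compounds shown, and "the series" means these compounds.

Values in a functional assay on U-251 cells (Homo sapiens); a higher number here means a weaker inhibitor of growth, a lower number a stronger inhibitor of growth:
- Compound 1 `O=S(=O)(/C=C/c1ccc(Cl)c(Cl)c1)Cc1ccc(Nc2ncnc3ccc(Br)cc23)cc1`: > 100000 nM (a limit of the assay, not a number)
- Compound 2 `O=S(=O)(/C=C/c1ccc(Cl)cc1Cl)Cc1ccc(Nc2ncnc3ccc(Br)cc23)cc1`: 4000 nM
- Compound 3 `O=S(=O)(/C=C/c1ccc(C(F)(F)F)cc1F)Cc1ccc(Nc2ncnc3ccc(Br)cc23)cc1`: 30000 nM

Compound 3, at 30000 nM, holds the higher of the two actual numbers. Compound 1 reports only a limit. Compound 4 `O=S(=O)(/C=C/c1ccc(F)cc1F)Cc1ccc(Nc2ncnc3ccc(Br)cc23)cc1`, not yet measured, differs from compound 3 by fluoro in place of trifluoromethyl on an aromatic carbon, which gives 2,4-difluorophenyl.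

Going by the values given here, no measured step makes this exact change. The closest is a 7.5-fold higher number from compound 2 to compound 3 (0.88 log units; beyond the scatter), where 2-fluoro-4-(trifluoromethyl)phenyl replaces 2,4-dichlorophenyl. The steps of an at least 25-fold lower number from compound 1 to compound 2 (1.39 log units; beyond the scatter) and an at least 3.3-fold lower number from compound 1 to compound 3 (0.52 log units; beyond the scatter) start from the limit, but they show that this assay responds to changes in this aryl group. Since 2,4-difluorophenyl shares its substitution places with the 2,4-dichlorophenyl of compound 2, at 4000 nM, a modest move towards a lower number is expected. The expected step is a 2.5-fold lower number from compound 3 to compound 4 (0.40 log units; beyond the scatter), though a result within the scatter would not be surprising. The estimate for compound 4 is 12000 nM, with an expected range of 3000 nM to 50000 nM.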

Compound 4, concentration for 50% growth inhibition: 32000 nM
Compound 4: the middle estimate sits 2.7-fold (0.43 log units) below what was measured; the measured number falls inside the stated range.
By their numbers in this assay, from the lowest: compound 2; then compounds 3 and 4 (each within the scatter of the next). At a limit, above all of these: compound 1.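

In this assay, fluoro and trifluoromethyl at this place, para to a large group, do not separate, with a 1.1-fold higher number from compound 3 to compound 4 (0.03 log units; within the scatter). Keeping the same substitution places does not carry the activity of compound 2 over to the fluoro analogue, with an 8.0-fold higher number from compound 2 to compound 4 (0.90 log units; beyond the scatter), so among the compounds with a number, 2,4-dichlorophenyl alone stands apart. The remaining step, an at least 3.1-fold lower number from compound 1 to compound 4 (0.49 log units; beyond the scatter), starts from a limit of the assay held by compound 1, not a number, and gives only a bound: the limit of > 100000 nM in this assay, at which 1 of the 4 values shown sits.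

The compounds shown do not separate the two chloro groups of compound 2, so which of them accounts for the gap stays open. Also open, on these data alone, is how an amine or a methoxy group at this place would read in this assay.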